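A few compounds are considered here, and "the series" means these few. Any claim that something is new, unique, unknown or untested is made for them only; others in the source may bear on it.

Compound 1 `CC1(C)Cc2c(sc(NC(=O)C3(CO)CC3)c2C(N)=O)C(C)(C)O1` gives 1320 nM in an assay on cells for positive allosteric modulation of Cystic fibrosis transmembrane conductance regulator variant G551D (Homo sapiens), with stated times of 10 min and 2 min, in the presence of a further agent that is not named here (a higher number here means that more compound is needed for the effect, a lower number that less compound is needed), the highest of the three numbers measured. Compound 2 `CC(C)(C)CC(O)C(=O)Nc1sc2c(c1C(N)=O)CC(C)(C)OC2(C)C` gives 981 nM, and compound 3 `Cc1cc(C(=O)Nc2sc3c(c2C(N)=O)CC(C)(C)OC3(C)C)[nH]n1` gives 590 nM. The step of a 1.3-fold lower number from compound 1 to compound 2 (0.13 log units; within the scatter) stays within the scatter, while a 2.2-fold lower number from compound 1 to compound 3 (0.35 log units; beyond the scatter) is a modest change beyond it. Compound 4 `Cc1n[nH]c(C(=O)Nc2sc3c(c2C(N)=O)CC(C)(C)OC3(C)C)c1Cl` differs from compound 1 in that (a group of 7 heavy atoms (4 carbon, 2 nitrogen, 1 chlorine; one five-membered aromatic ring with 2 hetero atoms) in place of a group of 5 heavy atoms (4 carbon, 1 oxygen; one three-membered non-aromatic ring of carbon only), on a carbonyl carbon). The step from compound 1 to compound 3 bears most directly on this, since the entering group in compound 4 also holds a five-membered aromatic ring with 2 hetero atoms, now carrying chlorine, so a similar modest fall is expected. Compound 4 is therefore estimated at 550 nM, between 250 nM and 1200 nM, an expected step of a 2.4-fold lower number from compound 1 to compound 4 (0.38 log units; beyond the scatter).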

Compound 4, half-maximal effective concentration: 199 nM
The estimate for compound 4 lay 2.8-fold (0.44 log units) above the measured number; measured number outside the range, below it.
By their numbers in this assay, from the lowest: compound 4; then compounds 3, 2 and 1 (each within the scatter of the next, the first and the last beyond it).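

Chloro in place of hydrogen on an aromatic carbon alone brings a 3.0-fold lower number from compound 3 to compound 4 (0.47 log units; beyond the scatter) in this assay, so this ring on the carbonyl carbon responds to a single added atom. The chlorinated ring also gives a 6.6-fold lower number from compound 1 to compound 4 (0.82 log units; beyond the scatter) and a 4.9-fold lower number from compound 2 to compound 4 (0.69 log units; beyond the scatter), clearing both ring-free and cyclopropyl-bearing groups, whereas compound 3 stood beyond the scatter only against compound 1. Nothing measured here gives a reason for this gain. From the compounds shown here alone, whether bromo, methyl or nitrile in that same place would match chloro remains open. So does whether chloro would bring a similar step on another aromatic ring.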